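This account rests on a few compounds, and the source may have more. Where it says the series, first, only, none or still open, it means among the compounds named here.

Measured so far in a functional assay on HepG2 cells (Homo sapiens) for antiproliferative activity, read by MTT assay, with a stated time of 48 h; a lower number here means a stronger inhibitor, a higher number a weaker inhibitor:
compound 1, `Cc1ccc(NC(=O)Nc2cccc(CNc3nccnc3Cl)c2)cc1`, 11500 nM
compound 2, `O=C(Nc1cccc(CNc2nccnc2Cl)c1)Nc1ccccc1Cl`, 8560 nM
compound 3, `O=C(Nc1ccccc1)Nc1cccc(CNc2nccnc2Cl)c1`, 15600 nM

Compound 1 gives the second highest of the three numbers in this assay; its steps to compound 2, a 1.3-fold lower number from compound 1 to compound 2 (0.13 log units; within the scatter), and to compound 3, a 1.4-fold higher number from compound 1 to compound 3 (0.13 log units; within the scatter), both fall within the scatter, so nothing separates the three. Compound 4, `CCc1ccccc1NC(=O)Nc1cccc(CNc2nccnc2Cl)c1`, is not yet measured. It differs from compound 1 in one place: 2-ethylphenyl in place of 4-methylphenyl on an amide-type nitrogen. The step that bears most on it is the earlier exchange of the group on the same amide-type nitrogen, a 1.3-fold lower number from compound 1 to compound 2 (0.13 log units; within the scatter); the remaining step, a 1.8-fold higher number from compound 2 to compound 3 (0.26 log units; within the scatter), also stays within the scatter. Nothing in these numbers points to a step beyond the scatter in this assay in either direction. Compound 4 is therefore expected to give 10500 nM (range 4500 nM to 24000 nM), a step of a 1.1-fold lower number from compound 1 to compound 4 (0.04 log units; within the scatter) that is expected to remain within the scatter.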

Compound 4, half-maximal inhibitory concentration: 7860 nM
The estimate for compound 4 lay 1.3-fold (0.13 log units) above the measured number; the range from low to high includes it.
By their numbers in this assay, from the lowest: compounds 4, 2, 1 and 3 (each within the scatter of the next).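

In this assay the larger 2-ethylphenyl on the amide-type nitrogen leaves the series flat: a 1.5-fold lower number from compound 1 to compound 4 (0.17 log units; within the scatter) and a 2.0-fold lower number from compound 3 to compound 4 (0.30 log units; within the scatter) and a 1.1-fold lower number from compound 2 to compound 4 (0.04 log units; within the scatter) all lie within the scatter. The earlier compounds shown here carried only chloro, methyl or hydrogen on the phenyl ring, so this position now also accepts ethyl without a readable shift. No measured evidence accounts for this flatness.

On these data alone, whether any group here can move the number beyond the scatter remains open, for example an amine, a carboxylic acid or a longer chain on that phenyl ring. As far as these compounds go, the effect of changes to the shared core also remains open.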